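The source may hold more compounds than are shown below. What is called first, only, known or untested is meant among the compounds shown, and "the series" means these compounds.

Working notes on the series. Among the measured compounds shown here, compound 1 `CCCCC(=O)N(Cc1ccc(OC)c(O)c1)c1cc(OC)c(OC)c(OC)c1` gives the lowest number of the three measured so far in a functional assay on HCT-116 cells (Homo sapiens) for inhibition, read by MTT assay, with a stated time of 48 h (a higher number here means a weaker inhibitor, a lower number a stronger inhibitor), at 170 nM. Compound 2 `C/C=C/C(=O)N(Cc1cc(OC)c(OC)c(OC)c1)c1ccc(OC)c(O)c1` gives 8450 nM in this assay, a number beyond the scatter away from compound 1. Compound 3 `COc1cc(NCc2cccc(O)c2)cc(OC)c1OC` gives 67700 nM in this assay, further still from compound 1. For the measured compounds named here, no single-change step between measured compounds is available, so the two larger numbers only show that compounds with a different acyl part or with no acyl part at all sit well above compound 1.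

Compound 4 `COc1ccc(CN(C(=O)CO)c2cc(OC)c(OC)c(OC)c2)cc1O` is the unmeasured neighbour of compound 1; it carries the change (hydroxy in place of propyl on a saturated chain carbon bound to a carbonyl carbon). The step from compound 1 to compound 4 is expected to go toward a higher number, most likely a moderate loss that is beyond the scatter, judged against how compound 2 at 8450 nM and compound 3 at 67700 nM stand relative to compound 1 at 170 nM. The expected step is an 8.8-fold higher number from compound 1 to compound 4 (0.95 log units; beyond the scatter). For compound 4 in this assay the estimate is 1500 nM, with a range from 300 nM to 8000 nM.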

Compound 4, half-maximal inhibitory concentration: 520 nM
For compound 4 the middle estimate is 2.9-fold (0.46 log units) above the measured one; low and high end bracket the measured number.
By their numbers in this assay, from the lowest: compound 1; then compound 4; then compound 2; then compound 3.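

In this assay the acyl part of compound 1 now has its first single-change reading: hydroxy in place of propyl on a saturated chain carbon bound to a carbonyl carbon gives a 3.1-fold higher number from compound 1 to compound 4 (0.49 log units; beyond the scatter) and stays a modest step, though beyond the scatter. The propyl group is therefore not needed for a number of this order, and this position accepts a hydrogen-bond donor and acceptor in its place at a limited cost, with compound 4 at 520 nM in this assay. No measurement at hand bears on why the number rises with this change.

The single step removes the propyl group and brings in the hydroxy group together, so the compounds shown cannot separate the effect of losing the chain from that of adding the hydroxy group. A methoxy group, an amine or a carboxylic acid on the same saturated chain carbon, or a longer chain carrying a terminal hydroxy group, would show whether the modest rise belongs to the hydroxy group or to the shorter chain.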